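Flipping One Ring Stereocentre in a Sugar-Linked Lactam

The source may hold more compounds than are shown below. What is called first, only, known or untested is meant among the compounds shown, and "the series" means these compounds.

Three compounds have been measured in a functional assay on RAW264.7 cells (Mus musculus) for inhibition, read by Griess assay, with a stated time of 24 h; a lower number here means a stronger inhibitor, a higher number a weaker inhibitor:

Compound 1, `C[C@@H]1O[C@@H](O[C@H]2COC(=O)C2)[C@H](O)[C@H](O)[C@H]1O`, gives 41200 nM.
Compound 2, `O=C1C[C@H](O[C@H]2O[C@H](CO)[C@@H](O)[C@H](O)[C@H]2O)CN1`, gives 80900 nM.
Compound 3, `C[C@@H]1O[C@@H](O[C@H]2CNC(=O)C2)[C@H](O)[C@H](O)[C@H]1O`, gives 116000 nM.

Compound 3 has the highest of the three numbers. Compound 2 sits close to it, inside the scatter, so no order between the two can be claimed; compound 1 lies lower by a margin beyond the scatter.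

Compound 4, `C[C@@H]1O[C@@H](O[C@@H]2CNC(=O)C2)[C@H](O)[C@H](O)[C@H]1O`, awaits measurement. Compared with compound 3, (the two compounds have the same atoms and bonds and differ only in configuration as drawn: 1 of 6 stereo elements differ; a stereocentre at a saturated ring carbon is drawn R in compound 3 and S in compound 4). No measured pair among these three shows what such an inversion does, so the direction is open. In this assay the expected step is a 1.2-fold lower number from compound 3 to compound 4 (0.06 log units; within the scatter), small enough that it may stay within the scatter. Compound 4 is therefore estimated at 100000 nM, with a range from 40000 nM to 300000 nM.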

Compound 4, half-maximal inhibitory concentration: 66900 nM
Estimate against measurement, compound 4: 1.5-fold (0.17 log units) above, and the stated range covers the measured number.
By their numbers in this assay, from the lowest: compounds 1, 4, 2 and 3 (each within the scatter of the next, the first and the last beyond it).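

Among the compounds shown here, compounds 3 and 4 form the first pair here that isolates a single stereocentre, and inverting that saturated ring carbon from R to S gives a 1.7-fold lower number from compound 3 to compound 4 (0.24 log units; within the scatter) in this assay. The two compounds therefore cannot be ordered, and this inversion shows no clear effect on the number. Any real gap between them could come only from that centre: the fact that compounds 3 and 4 differ only in the configuration as drawn.

On these data alone, what the same inversion does with the sugar of compound 2 stays open. So does whether an amine or a longer chain on that ring carbon would change the number by more.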